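The compounds below may be only part of what the source reports. "The series", "measured", "known", "first", "only" and "open" are said of these compounds alone.

Measured in an ADME assay on HOS cells (Homo sapiens) for cytotoxicity; on this read-out lower numbers stand for higher toxicity in this test and higher numbers for lower toxicity in this test:
- Compound 1 `CN(Cc1nc2ccccc2n1CCCCN)C1CCCc2cccnc21`: 2900 nM
- Compound 2 `CN(Cc1nc2ccccc2n1CCCNC(=O)C(F)(F)F)C1CCCc2cccnc21`: 10400 nM
- Compound 3 `CN(Cc1nc2cccc(C(=O)NCCCN)c2[nH]1)C1CCCc2cccnc21`: > 20000 nM

Compound 3 gives only a limit of the assay and no number, > 20000 nM.

Compound 4 `CN(C)CCCc1cccc2nc(CN(C)C3CCCc4cccnc43)[nH]c12` has not yet been measured. It carries 3-(dimethylamino)propyl in place of (3-aminopropyl)carbamoyl on an aromatic carbon.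

Among the compounds with values here, only one measured step bears on this change, and only indirectly, since it lies at another place on the shared core. This modest step is a 3.6-fold higher number from compound 1 to compound 2 (0.55 log units; beyond the scatter), where ((trifluoromethyl)carbonyl)amino replaces aminomethyl on a saturated chain carbon. It suggests that a chain with a carbonyl-bearing link can give a higher number than one ending in a plain amine. Compound 4 loses the carbonyl and keeps a chain ending in an amine, like compound 1 at 2900 nM, so a lower number is expected, though the size is uncertain. The expected change is an at least 1.8-fold lower number from compound 3 to compound 4 (0.25 log units; that floor lies within the scatter).

The estimated value for compound 4 is 11000 nM, within an expected range of 4000 nM to 20000 nM.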

Compound 4, half-maximal cytotoxic concentration: 7500 nM
Compound 4: the middle estimate sits 1.5-fold (0.17 log units) above what was measured, and the stated range covers the measured number.
By their numbers in this assay, from the lowest: compound 1; then compounds 4 and 2 (each within the scatter of the next). At a limit, above all of these: compound 3.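

In this assay, this position on an aromatic carbon of the six-membered aromatic ring proves sensitive to its substituent: 3-(dimethylamino)propyl in place of (3-aminopropyl)carbamoyl gives an at least 2.6-fold lower number from compound 3 to compound 4 (0.42 log units; beyond the scatter). For compound 3 the reading is a limit of the assay and not a number: the limit of > 20000 nM in this assay, at which 1 of the 4 values shown sits. The change removes the carbonyl and the amide hydrogen and also swaps the chain's primary amine for a dimethylamino end, so this single step shows the combined swap and cannot separate these parts.

As far as these compounds go, it remains open whether the carbonyl or the amine end accounts for the step. A plain 3-aminopropyl group or a carbamoyl chain ending in dimethylamino on this carbon would separate the two, and a longer chain would show whether length matters here.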